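Swapping Sulfur for Tellurium on a Shared Amide Core

The source may hold more compounds than are shown below. What is called first, only, known or untested is meant among the compounds shown, and "the series" means these compounds.

Compound 1 `COc1ccc(N(CC(=O)NCCCSc2ccccc2)C(=O)/C=C/c2ccccc2)cc1` was tested in a functional assay on MCF7 cells (Homo sapiens) for cytotoxicity, read by MTT assay, with a stated time of 24 h; on this read-out lower numbers stand for stronger inhibition and higher numbers for weaker inhibition. In this assay compound 1 gives >= 100000 nM, which is a limit of the assay rather than a number. Compound 2 `COc1ccc(N(CC(=O)NCCCSc2ccccc2)C(=O)C#Cc2ccccc2)cc1` gives >= 100000 nM, also a limit. Compound 3 `COc1ccc(N(CC(=O)NCCCSc2ccccc2)C(=O)c2ccccc2)cc1` gives >= 100000 nM, a limit as well. The steps a step that the two limits leave unreadable from compound 1 to compound 2, a step that the two limits leave unreadable from compound 1 to compound 3 and a step that the two limits leave unreadable from compound 2 to compound 3 therefore cannot be sized, because every value shown sits at the limit of >= 100000 nM in this assay, at which 3 of the 3 values shown sit. Compound 4 `COc1ccc(N(CC(=O)NCCC[Te]c2ccccc2)C(=O)/C=C/c2ccccc2)cc1` differs from compound 1 by a group of 7 heavy atoms (6 carbon, 1 tellurium; one six-membered aromatic ring of carbon only) in place of a group of 7 heavy atoms (6 carbon, 1 sulfur; one six-membered aromatic ring of carbon only), on a saturated chain carbon, three bonds along the chain from an amide-type nitrogen. Among the compounds with values here, none of the measured steps touches this sulfur-bearing group, so the expectation rests on the shared limit alone. Compound 4 is expected to show 80000 nM, with a range from 15000 nM to 300000 nM. The step this expectation means is an at least 1.2-fold lower number from compound 1 to compound 4 (0.09 log units; that floor lies within the scatter).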

Compound 4, half-maximal inhibitory concentration: 2000 nM
The estimate for compound 4 lay 40-fold (1.60 log units) above the measured number; measured number outside the range, below it.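

Replacing the sulfur of the phenylsulfanyl group with tellurium, on a saturated chain carbon, gives an at least 50-fold lower number from compound 1 to compound 4 (1.69 log units; beyond the scatter) in this assay. The earlier steps shown here changed only the group on the carbonyl carbon, and none of them could be read. Compound 4 is the only compound shown with a number rather than a limit, so this one atom exchange is enough to move the read-out off the value shared by the others: the limit of >= 100000 nM in this assay, at which 3 of the 4 values shown sit.

As far as these compounds go, whether the same exchange would act on compound 2 and compound 3 stays open. So does what selenium would do in the same place.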